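Trimming a Methoxy on a Triazole-Linked Scaffold

This account rests on a few compounds, and the source may have more. Where it says the series, first, only, none or still open, it means among the compounds named here.

Compound 1 `COc1cc(OC)cc(-n2cc(-c3ccc(OC)c(O)c3)nn2)c1`, compound 2 `COc1ccc(-c2cn(-c3cc(OC)c(OC)c(OC)c3)nn2)cc1O` and compound 3 `COc1cc(OC)cc(-c2cn(-c3cc(OC)c(OC)c(OC)c3)nn2)c1` were each examined in a functional assay on MDA-MB-231 cells (Homo sapiens) for cytotoxicity, read by MTT assay; on this read-out lower numbers stand for stronger inhibition and higher numbers for weaker inhibition. In this assay compound 1 gives only a limit, > 10000 nM. Compound 2 likewise gives only a limit, > 10000 nM. Compound 3 also gives only a limit, > 10000 nM. The difference between the cores of compound 2 and compound 3 is not broken down here. From compound 2 to compound 1 the change is hydrogen in place of methoxy on an aromatic carbon, and the step that the two limits leave unreadable from compound 2 to compound 1 stays unreadable because of the limit of > 10000 nM in this assay, at which 3 of the 3 values shown sit. Compound 4 `COc1cc(OC)cc(-c2cn(-c3ccc(OC)c(OC)c3)nn2)c1` carries the same kind of change relative to compound 3, (hydrogen in place of methoxy on an aromatic carbon), though here the place is ortho to a methoxy group, meta to a large group and meta to a methoxy group, rather than ortho to two methoxy groups and para to a large group. Because compound 3 rests at the limit > 10000 nM, the step that the limit leaves unreadable from compound 3 to compound 4 is expected to be small. Compound 4 is therefore estimated at 15000 nM, most likely again only a limit.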

Compound 4, half-maximal inhibitory concentration: 10000 nM
Compound 4: the middle estimate sits 1.5-fold (0.18 log units) above what was measured; low and high end bracket the measured number.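

In this assay, hydrogen in place of methoxy on an aromatic carbon gives a number no higher from compound 3 to compound 4 (the limit leaves the size open), and compound 4 stands at 10000 nM. Compound 3 gives only a limit, > 10000 nM. The same change from compound 2 to compound 1 is also unreadable in size, so the data show neither that the change carries from one core to the other nor that it fails to, because the values gather at one limit: the limit of > 10000 nM in this assay, at which 3 of the 4 values shown sit.

The compounds shown leave open whether any change on these cores would give a value clearly under this level. From the compounds shown here alone, it also remains open whether an amine or a carboxylic acid in place of that methoxy would yield a readable step in this assay.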